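A few compounds are considered here, and "the series" means these few. Any claim that something is new, unique, unknown or untested is made for them only; others in the source may bear on it.

In a functional assay on MCF7 cells (Homo sapiens) for cytotoxicity, read by MTT assay, with a stated time of 72 h (on this read-out higher numbers stand for weaker inhibition and lower numbers for stronger inhibition), three compounds built on a shared core have been measured: compound 1 (`O=C1C(=Cc2ccc(O)cc2)C(=O)N(c2ccc(Cl)cc2)N1c1ccc(Cl)cc1`) gives 23200 nM as its number, compound 2 (`O=C1C(=Cc2ccc(Cl)cc2)C(=O)N(c2ccc(Cl)cc2)N1c1ccc(Cl)cc1`) gives 28500 nM as its number, and compound 3 (`COc1cc(C=C2C(=O)N(c3ccc(Cl)cc3)N(c3ccc(Cl)cc3)C2=O)ccc1O`) gives 22800 nM as its number. Compound 3 therefore stands level with the other two, all within the scatter. In compound 4 (`O=C1C(=Cc2cccc(Cl)c2)C(=O)N(c2ccc(Cl)cc2)N1c1ccc(Cl)cc1`), 3-chlorophenyl takes the place of 4-hydroxy-3-methoxyphenyl on a double-bonded chain carbon bound to a double-bonded ring carbon (3-chlorophenyl in place of 4-hydroxy-3-methoxyphenyl on a double-bonded chain carbon bound to a double-bonded ring carbon). The closest measured change is a 1.3-fold lower number from compound 2 to compound 3 (0.10 log units; within the scatter) as 4-hydroxy-3-methoxyphenyl replaces 4-chlorophenyl at that same place. Two further changes on that ring gave a 1.2-fold higher number from compound 1 to compound 2 (0.09 log units; within the scatter) and a 1.0-fold lower number from compound 1 to compound 3 (0.01 log units; within the scatter) as their results. All three steps are small, but none compares 3-chlorophenyl with 4-chlorophenyl, so some uncertainty remains. The expected change is a 1.1-fold higher number from compound 3 to compound 4 (0.06 log units; within the scatter) and no shift beyond the scatter. The estimate for compound 4 is 26000 nM with an expected range from 14000 nM to 48000 nM around it.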

Compound 4, half-maximal inhibitory concentration: 18300 nM
Compound 4: the middle estimate sits 1.4-fold (0.15 log units) above what was measured, within the range that was stated.
By their numbers in this assay, from the lowest: compounds 4, 3, 1 and 2 (each within the scatter of the next).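

Set against 4-chlorophenyl at this place on the double-bonded chain carbon, 3-chlorophenyl gives a 1.6-fold lower number from compound 2 to compound 4 (0.19 log units; within the scatter) in this assay, a direct comparison of the two chlorophenyl groups that the earlier compounds did not offer. Against the two groups that carry oxygen, it gives a 1.2-fold lower number from compound 3 to compound 4 (0.10 log units; within the scatter) and a 1.3-fold lower number from compound 1 to compound 4 (0.10 log units; within the scatter). Compound 4 has 0 hydrogen-bond donors and 0 hydrogen-bond acceptors in this group, yet it stays level with compound 3, whose group has both, so all four groups shown here give numbers within the scatter of one another.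

No measurement is available that would explain why these numbers stay level. Going by these compounds, it remains open whether a different kind of group at this place, such as an amine, a carboxylic acid or a longer chain, would shift the number beyond the scatter.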